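From 2-nitrophenyl to 4-methoxyphenyl on the shared core

A few compounds are considered here, and "the series" means these few. Any claim that something is new, unique, unknown or untested is made for them only; others in the source may bear on it.

For the measured compounds named here, in a functional assay on A549 cells (Homo sapiens) for cytotoxicity, read by MTT assay, with a stated time of 72 h (on this read-out higher numbers stand for weaker inhibition and lower numbers for stronger inhibition), compound 1 (`O=C(/C=C/c1cccc(Cl)c1Cl)Nc1cc2c(Nc3ccc(F)c(Cl)c3)ncnc2cc1O[C@H]1CCOC1`) gives 23200 nM and compound 2 (`O=C(/C=C/c1ccccc1[N+](=O)[O-])Nc1cc2c(Nc3ccc(F)c(Cl)c3)ncnc2cc1O[C@H]1CCOC1`) gives 8820 nM as the lower of the two numbers so far. Compound 3 (`COc1ccc(/C=C/C(=O)Nc2cc3c(Nc4ccc(F)c(Cl)c4)ncnc3cc2O[C@H]2CCOC2)cc1`) keeps the shared core and carries 4-methoxyphenyl in place of 2-nitrophenyl on a double-bonded chain carbon bound to a double-bonded chain carbon. Going by the values given here, only one measured step bears on this place: 2-nitrophenyl in place of 2,3-dichlorophenyl gave a 2.6-fold lower number from compound 1 to compound 2 (0.42 log units; beyond the scatter) as a modest change. Among the compounds with values here, no measurement yet covers 4-methoxyphenyl, so only a modest move toward a higher number in this assay is expected, probably no larger than that step. The expected change is a 1.6-fold higher number from compound 2 to compound 3 (0.20 log units; within the scatter) as an estimate only. Compound 3 is estimated at 14000 nM (expected range 5000 nM to 38000 nM).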

Compound 3, half-maximal inhibitory concentration: 3050 nM
Beside the measured number, compound 3's estimate is 4.6-fold (0.66 log units) above it; measured number outside the range, below it.
By their numbers in this assay, from the lowest: compound 3; then compound 2; then compound 1.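

In this assay, the step to 4-methoxyphenyl gives a 2.9-fold lower number from compound 2 to compound 3 (0.46 log units; beyond the scatter) and the step from the dichlorinated group gives a 7.6-fold lower number from compound 1 to compound 3 (0.88 log units; beyond the scatter), so compound 3 has the lowest number of the three. This position therefore does not depend on 2-nitrophenyl or 2,3-dichlorophenyl for a low number, and a phenyl group with a single methoxy substituent reads lower than both. Nothing available explains this order.

Since 4-methoxyphenyl differs from each earlier group in both its substituent and where that substituent sits, the compounds shown cannot separate these two changes. On these data alone, whether 2-methoxyphenyl, 4-nitrophenyl or an unsubstituted phenyl would read like compound 3 stays open, as does the effect of a longer alkoxy chain in place of the methoxy group.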